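A few compounds are considered here, and "the series" means these few. Any claim that something is new, unique, unknown or untested is made for them only; others in the source may bear on it.

Of the compounds shown here, three sharing one core have been measured in an assay on HEK293 cells for inhibition of acid ceramidase (Homo sapiens), with a stated time of 10 min; a lower number here means a stronger inhibitor, a higher number a weaker inhibitor. Compound 1 `O=C(NCCCCc1ccccc1)n1c(=O)oc2ccccc21` gives 64 nM, compound 2 `O=C(NCCCCc1ccccc1)n1c(=O)oc2ccc(Br)cc21` gives 22 nM, and compound 3 `O=C(NCCCCCCc1ccccc1)n1c(=O)oc2ccccc21` gives 51 nM. Compound 2 thus stands lowest of the three measured numbers. Compound 4 `O=C(NCCCCc1ccccc1)n1c(=O)oc2ccc(-c3ccc(F)cc3)cc21` differs from compound 2 by a single change: 4-fluorophenyl in place of bromo on an aromatic carbon. Among the compounds with values here, the only measured step at that aromatic carbon is a 2.9-fold lower number from compound 1 to compound 2 (0.46 log units; beyond the scatter), where a bromo entered in place of hydrogen; no measured step shows what a 4-fluorophenyl does there. The chain step a 1.3-fold lower number from compound 1 to compound 3 (0.10 log units; within the scatter) concerns a different part of the molecule and does not bear on it. Compound 4 is therefore expected to give about 25 nM, within a range from 10 nM to 60 nM. The estimated step from compound 2 to compound 4 would be a 1.1-fold higher number from compound 2 to compound 4 (0.06 log units; within the scatter), which is no change beyond the scatter.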

Compound 4, half-maximal inhibitory concentration: 56 nM
For compound 4 the middle estimate is 2.2-fold (0.35 log units) below the measured one; low and high end bracket the measured number.
By their numbers in this assay, from the lowest: compound 2; then compounds 3, 4 and 1 (each within the scatter of the next).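

In this assay the swap of bromo for 4-fluorophenyl gives a 2.5-fold higher number from compound 2 to compound 4 (0.41 log units; beyond the scatter) and so this aromatic carbon does not treat every added group alike. Set against the core of compound 1, 4-fluorophenyl in place of hydrogen gives a 1.1-fold lower number from compound 1 to compound 4 (0.06 log units; within the scatter) which means the gain seen with bromo is not kept with this larger group. Nothing measured here explains the difference. Still open, going by these compounds, is how a chloro, a methyl, an amine or a carboxylic acid would fare at this carbon, and whether a plain phenyl would match 4-fluorophenyl.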